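Replacing 4-cyanophenyl with 3,5-dimethoxyphenyl in the series

The source may report more compounds than this note shows. Statements on the series, on what has been measured and on what is new or still open speak of the compounds shown alone.

Measured in a functional assay on QGY-7703 cells (Homo sapiens) for cytotoxicity, read by MTT assay, with a stated time of 24 h; on this read-out lower numbers stand for stronger inhibition and higher numbers for weaker inhibition:
- compound 1 `COc1cc(/C=C2\CN(S(=O)(=O)c3ccc(F)cc3)C/C(=C\c3cc(OC)cc(OC)c3)C2=O)cc(OC)c1` gives 11400 nM
- compound 2 `COc1cc(/C=C2\CN(S(=O)(=O)c3ccc(F)cc3)C/C(=C\c3ccccc3F)C2=O)cc(OC)c1` gives 14000 nM
- compound 3 `COc1cc(/C=C2\CN(S(=O)(=O)c3ccc(F)cc3)C/C(=C\c3ccc(C#N)cc3)C2=O)cc(OC)c1OC` gives 4980 nM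

Compound 3 has the lowest number of the three, and its gaps to compound 1 and compound 2 both lie beyond the scatter. Next for this assay is compound 4 `COc1cc(/C=C2\CN(S(=O)(=O)c3ccc(F)cc3)C/C(=C\c3cc(OC)c(OC)c(OC)c3)C2=O)cc(OC)c1`. On a double-bonded chain carbon bound to a double-bonded ring carbon, it has 3,5-dimethoxyphenyl in place of 4-cyanophenyl (3,5-dimethoxyphenyl in place of 4-cyanophenyl on a double-bonded chain carbon bound to a double-bonded ring carbon).

One measured step falls at this place: a 1.2-fold higher number from compound 1 to compound 2 (0.09 log units; within the scatter). In that step 3,5-dimethoxyphenyl gives way to 2-fluorophenyl, and the change stays within the scatter. Going by the values given here, no measured step shows 4-cyanophenyl leaving. Compound 1, which also carries 3,5-dimethoxyphenyl at this place, stands at 11400 nM, so a move from compound 3 towards that level is expected. The estimated change is a 1.8-fold higher number from compound 3 to compound 4 (0.26 log units; within the scatter), a higher number, though it may not clear the scatter. Compound 4 is estimated at 9000 nM, with an expected range of 4500 nM to 18000 nM.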

Compound 4, half-maximal inhibitory concentration: 5200 nM
Estimate against measurement, compound 4: 1.7-fold (0.24 log units) above, within the range that was stated.
By their numbers in this assay, from the lowest: compounds 3 and 4 (each within the scatter of the next); then compounds 1 and 2 (each within the scatter of the next).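

In this assay, the exchange at this place leaves the number unchanged within the scatter, a 1.0-fold higher number from compound 3 to compound 4 (0.02 log units; within the scatter), so 4-cyanophenyl and 3,5-dimethoxyphenyl are not told apart here. A single added group does register: methoxy in place of hydrogen on an aromatic carbon gives a 2.2-fold lower number from compound 1 to compound 4 (0.34 log units; beyond the scatter), and 3,4,5-trimethoxyphenyl in place of 2-fluorophenyl gives a 2.7-fold lower number from compound 2 to compound 4 (0.43 log units; beyond the scatter), both modest but, unlike the earlier step at this place, beyond the scatter. Nothing at hand explains these steps.

Still open, on these data alone, is whether the lower number depends on methoxy itself, or whether a hydroxyl or an amine on the same aromatic carbon would serve equally. A longer chain such as ethoxy in place of that methoxy also remains untested among the compounds shown.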